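Phenyl to 2-Chlorobenzyl on the Amide Nitrogen

The source may report more compounds than this note shows. Statements on the series, on what has been measured and on what is new or still open speak of the compounds shown alone.

Three compounds sharing one core have been examined on liver-derived cells. Compound 1 `CC(Sc1nnc(-c2ccncc2)s1)C(=O)Nc1c(Cl)cccc1Cl` gives > 50000 nM in an ADME assay on HepG2 cells (Homo sapiens) for cytotoxicity, with a stated time of 3 days; a lower number here means that less compound is tolerated, a higher number that more compound is tolerated; this is a limit of the assay rather than a number. Compound 2 `O=C(CCSc1nnc(-c2ccncc2)s1)Nc1ccccc1` likewise reaches only a limit in this assay, > 50000 nM. For compound 3 `O=C(CSc1nnc(-c2ccncc2)s1)NCc1ccccc1Cl` the entry in this assay reads "not determined" (no result reported), so no result is reported for it. Compound 2 therefore stands at the limit, as does compound 1, which is summarised by the limit of > 50000 nM in this assay, at which 2 of the 3 values shown sit; no single number places it above or below any other compound.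

Compound 4 `O=C(CCSc1nnc(-c2ccncc2)s1)NCc1ccccc1Cl` differs from compound 2 by 2-chlorobenzyl in place of phenyl on an amide-type nitrogen. Within the data shown here, no step between measured compounds is available to calibrate this change, so its effect can only be anticipated. Since compound 2 sits at the limit of this assay, compound 4 is expected to show a number no higher from compound 2 to compound 4 (the limit leaves the size open), a step of no size beyond the scatter. Compound 4 is estimated at 50000 nM, within 20000 nM to 100000 nM, most probably reported again as a limit rather than a number.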

Compound 4, half-maximal cytotoxic concentration: > 50000 nM
Compound 4 gave a limit, no number; the forecaster's own chance of this, stated with the estimate: 75%; the middle value sits exactly at the limit.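

Compound 2 and compound 4 both reach only a limit in this assay, so no step can be read between them. The compounds shown leave open whether 2-chlorobenzyl in place of phenyl on an amide-type nitrogen alters cytotoxicity at all, and at what concentration any cytotoxicity would appear.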